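Cytotoxicity Limits Across Three Ethers of One Core

The source may hold more compounds than are shown below. What is called first, only, known or untested is meant among the compounds shown, and "the series" means these compounds.

Of the compounds shown here, three sharing one core have been tested in an ADME assay on HEL cells (Homo sapiens) for cytotoxicity, with a stated time of 3 days (on this read-out higher numbers stand for lower toxicity in this test and lower numbers for higher toxicity in this test), and none of them gave a number, only a limit. Compound 1 `CCC1(Cc2ccccc2)OS(=O)(=O)C=C1OCc1ccccc1` gives >= 50000 nM, which is a limit. Compound 2 `CCC1(Cc2ccccc2)OS(=O)(=O)C=C1OCc1ccccc1Cl` gives >= 20000 nM, also a limit. Compound 3 `CCC1(Cc2ccccc2)OS(=O)(=O)C=C1OCCCc1ccccc1` gives >= 20000 nM, again a limit. Compound 3 therefore stands at the limit of >= 20000 nM in this assay, at which 2 of the 3 values shown sit, while the limit of >= 50000 nM in this assay, at which 1 of the 3 values shown sits, is the other limit recorded. The steps a step that the two limits leave unreadable from compound 1 to compound 2, a step that the two limits leave unreadable from compound 1 to compound 3 and a step that the two limits leave unreadable from compound 2 to compound 3 are all hidden behind these limits. Compound 4 `CCC1(Cc2ccccc2)OS(=O)(=O)C=C1OCC=C(C)C` differs from compound 3 by 2-methylprop-1-en-1-yl in place of phenethyl on a saturated chain carbon bound to an oxygen on an unsaturated carbon. With every measured step unreadable, no direction can be drawn from them. Compound 4 is expected to give 30000 nM, within a range of 10000 nM to 100000 nM, so that the expected step is a step that the limit leaves unreadable from compound 3 to compound 4 in this assay.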

Compound 4, minimum cytotoxic concentration: 400000 nM
Compound 4: the middle estimate sits 13-fold (1.12 log units) below what was measured, and the stated range ends below it.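

None of the steps from compound 1, compound 2 or compound 3 to compound 4 can be read: those first three values are limits. The compounds shown leave open whether 2-methylprop-1-en-1-yl in place of phenethyl changes the result in this assay at all, and in which direction.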